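Swapping the urea substituent on the piperazine of compound 3

The source may report more compounds than this note shows. Statements on the series, on what has been measured and on what is new or still open speak of the compounds shown alone.

The compounds here share a core in which a triazole bearing a benzyl group is linked through a dithiocarbamate to a piperazine that carries a urea. Compound 3 `Cc1ccc(Cn2cc(CSC(=S)N3CCN(C(=O)NC(C)C)CC3)nn2)cc1` gives 4630 nM in a functional assay on MCF7 cells (Homo sapiens) for cytotoxicity, read by MTT assay, with a stated time of 72 h; on this read-out lower numbers stand for stronger inhibition and higher numbers for weaker inhibition. Compound 1 `CCN(C)C(=O)N1CCN(C(=S)SCc2cn(Cc3ccccc3F)nn2)CC1`, which carries a different benzyl group and a different urea, gives 7210 nM in this assay, a number within the usual scatter of that of compound 3. Compound 2 `Cc1ccc(Cn2cc(CSC(=S)N3CCN(C(N)=O)CC3)nn2)cc1` reaches only a limit of this assay, > 128000 nM, rather than a number. For the measured compounds named here, the one measured step that changes the urea, an at least 27-fold lower number from compound 2 to compound 3 (1.44 log units; beyond the scatter), shows that a substituent on the urea nitrogen matters greatly.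

Compound 4 `CCN(C)C(=O)N1CCN(C(=S)SCc2cn(Cc3ccc(C)cc3)nn2)CC1` differs from compound 3 by ethyl(methyl)amino in place of isopropylamino on a carbonyl carbon. Going by the values given here, no measured step follows exactly this change, but the ethyl(methyl) urea of compound 4 also sits in an active compound, since in this assay compound 1 gives 7210 nM. Compound 4 is therefore expected to stay near compound 3, with a step of a 1.3-fold higher number from compound 3 to compound 4 (0.11 log units; within the scatter) in this assay, not beyond the scatter. Compound 4 is estimated at 6000 nM in this assay, with a range from 2500 nM to 15000 nM.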

Compound 4, half-maximal inhibitory concentration: 40100 nM
For compound 4 the middle estimate is 6.7-fold (0.82 log units) below the measured one; measured number above the stated range.
By their numbers in this assay, from the lowest: compounds 3 and 1 (each within the scatter of the next); then compound 4. At a limit, above all of these: compound 2.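

This result shows that the exact group on the carbonyl carbon matters, not only the presence of a substituent on the urea. Isopropylamino and ethyl(methyl)amino have the same heavy atoms, yet isopropylamino has one hydrogen-bond donor and ethyl(methyl)amino has none, and in this assay the change gives an 8.7-fold higher number from compound 3 to compound 4 (0.94 log units; beyond the scatter). The benzyl group also counts with this urea, as 4-methylphenyl in place of 2-fluorophenyl gives a 5.6-fold higher number from compound 1 to compound 4 (0.75 log units; beyond the scatter), so the activity of one ethyl(methyl) urea does not carry over to another compound with a different aryl group, while ethyl(methyl)amino in place of amino gives an at least 3.1-fold lower number from compound 2 to compound 4 (0.50 log units; beyond the scatter), a step that rests on a limit rather than a number and sets only a bound: the limit of > 128000 nM in this assay, at which 1 of the 4 values shown sits.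

The compounds shown leave open whether the amide hydrogen itself is what counts, as the step from isopropylamino to ethyl(methyl)amino removes that hydrogen and rearranges the carbons at once; ethylamino and dimethylamino at this place would help to separate the two. Going by these compounds, it also remains open whether isopropylamino would behave the same way on a compound carrying 2-fluorophenyl.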